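The source may hold more compounds than are shown below. What is called first, only, known or untested is meant among the compounds shown, and "the series" means these compounds.

Compound 3 `O=C1CCCN1c1cnc(NCc2c(F)ccc3c2CCO3)c2cn[nH]c(=O)c12` stands lowest of the three measured compounds in a physicochemical assay for lipophilicity, using the shake flask method, in phosphate buffer, measured as octanol-water partition, with a stated time of 30 min, at pH 7.4 (on this read-out higher numbers stand for higher lipophilicity and lower numbers for lower lipophilicity), giving 1.8. Compound 1 `Cc1cc(-c2cnc(NCc3c(F)ccc4c3CCO4)c3cn[nH]c(=O)c23)n(C)n1` gives 3, and compound 2 `Cn1cc(-c2cnc(NCc3c(F)ccc4c3CCO4)c3cn[nH]c(=O)c23)cn1` gives 2.7. Compound 4 `Cc1nc(CN(C)C)ccc1-c1cnc(NCc2c(F)ccc3c2CCO3)c2cn[nH]c(=O)c12` has not yet been measured; it differs from compound 3 in one place: 6-((dimethylamino)methyl)-2-methylpyridin-3-yl in place of 2-oxopyrrolidin-1-yl on an aromatic carbon. The two measured steps that bear on this are those in which 2-oxopyrrolidin-1-yl replaced an aromatic five-membered ring at the same position: a number 1.20 log units lower from compound 1 to compound 3 (beyond the scatter) and a number 0.90 log units lower from compound 2 to compound 3 (beyond the scatter). Read in reverse, an aromatic ring entering here would be expected to raise the number, although the entering group is larger and of a different kind, so the size is uncertain. Compound 4 is therefore expected to give about 2.2, between 1.3 and 3.1, an expected rise of a number 0.40 log units higher from compound 3 to compound 4 (beyond the scatter).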

Compound 4, distribution coefficient: 2
Beside the measured number, compound 4's estimate is 0.20 log units above it, and the stated range covers the measured number.
By their numbers in this assay, from the lowest: compounds 3 and 4 (each within the scatter of the next); then compounds 2 and 1 (each within the scatter of the next).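

In this assay, 6-((dimethylamino)methyl)-2-methylpyridin-3-yl gives a number 0.20 log units higher from compound 3 to compound 4 (within the scatter) in place of 2-oxopyrrolidin-1-yl, so an aromatic ring on this carbon does not by itself guarantee a higher number. The same group gives a number 0.70 log units lower from compound 2 to compound 4 (beyond the scatter) and a number 1.00 log units lower from compound 1 to compound 4 (beyond the scatter) when set against the two pyrazole groups, so aromatic groups here can differ widely from one another. No measurement shown explains this.

As far as these compounds go, the pyridine ring and its (dimethylamino)methyl arm change together here, so their separate contributions remain open. A plain phenyl ring, or the 2-methylpyridin-3-yl ring without the amine, could separate them.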